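The compounds below may be only part of what the source reports. "The series", "measured", "known", "first", "only" and "open" are said of these compounds alone.

Of the compounds shown here, three that share one core have been measured in an assay on Sf9 cells for inhibition of protein deacetylase HDAC6 (Homo sapiens), read by fluorescence, with stated times of 90 min and 30 min; a lower number here means a stronger inhibitor, a higher number a weaker inhibitor. Compound 1 `O=C(CCN(Cc1ccc(C(=O)NO)cc1)C(=O)c1ccccc1)NCc1ccccc1` gives 12.5 nM. Compound 2 `Cc1ccc(CNC(=O)CCN(Cc2ccc(C(=O)NO)cc2)C(=O)c2ccc(N(C)C)cc2)cc1` gives 14.4 nM, and compound 3 `CN(C)c1ccc(C(=O)N(CCC(=O)NCc2ccc(Cl)cc2)Cc2ccc(C(=O)NO)cc2)cc1` gives 10 nM. Compound 3 has the lowest of the three numbers, but both neighbours lie within the scatter of it, so no order among the three can be read from these numbers. Among the measured compounds shown here, the one step between two measured compounds that differ in a single place, a 1.4-fold lower number from compound 2 to compound 3 (0.16 log units; within the scatter), puts a chloro in place of a methyl on an aromatic carbon and stays within the scatter.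

Compound 4 `CN(C)c1ccc(C(=O)N(CCC(=O)NCc2ccccc2)Cc2ccc(C(=O)NO)cc2)cc1` differs from compound 3 by hydrogen in place of chloro on an aromatic carbon. This change, hydrogen in place of chloro on an aromatic carbon para to a large group, resembles the measured step in kind, since both concern the group at the far end of the benzylamino part, and that step was small. Compound 1 also carries a benzylamino rather than a (4-chlorobenzyl)amino group, though with a different benzoyl group, and its value sits close to that of compound 3. The expectation for this assay is therefore a step of a 1.2-fold higher number from compound 3 to compound 4 (0.08 log units; within the scatter), not larger than the scatter. Compound 4 is estimated at 12 nM, with a range from 6 nM to 25 nM.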

Compound 4, half-maximal inhibitory concentration: 14.8 nM
The estimate for compound 4 lay 1.2-fold (0.09 log units) below the measured number; the measured number falls inside the stated range.
By their numbers in this assay, from the lowest: compounds 3, 1, 2 and 4 (each within the scatter of the next).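

In this assay, taking the chloro off the 4-chlorobenzyl group gives a 1.5-fold higher number from compound 3 to compound 4 (0.17 log units; within the scatter), so the plain benzyl group cannot be told apart from its chlorinated form at this position. The change from methyl to hydrogen at the same place gives a 1.0-fold higher number from compound 2 to compound 4 (0.01 log units; within the scatter), which means that hydrogen, methyl and chloro at this position are now all linked by steps that stay within the scatter. The result also adds a single change at the other end of the molecule, where dimethylamino in place of hydrogen on the benzoyl group gives a 1.2-fold higher number from compound 1 to compound 4 (0.07 log units; within the scatter), so this position shows no readable effect either.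

No evidence is available on what lies behind these small steps. The compounds shown cover only small, uncharged groups on the two rings, so it remains open whether a carboxylic acid or an amine at the position of the chloro, or a longer chain leading to the benzyl ring, would shift the number beyond the scatter.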